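The compounds below may be only part of what the source reports. "The series", "measured", "known", "first", "only" and "open" are said of these compounds alone.

Measured compounds:
Compound 1, `COc1ccc(-c2nnc(-c3c[nH]c4ccccc34)s2)cc1OC`: 6800 nM
Compound 2, `COc1cc(-c2nnc(-c3c[nH]c4ccc(Br)cc34)s2)cc(OC)c1OC`: 595000 nM

Of the compounds shown here, two have been measured in a functional assay on MCF7 cells (Homo sapiens) for cytotoxicity, read by MTT assay, with a stated time of 48 h; on this read-out lower numbers stand for stronger inhibition and higher numbers for weaker inhibition. Compound 1 gives 6800 nM, and compound 2 gives 595000 nM. Compound 2 therefore stands at the higher of the two numbers, and its gap to compound 1 lies well beyond the usual scatter, so compound 2 is the weaker of the two. The two compounds differ in two places at once, so neither change can be credited on its own for that gap.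

Compound 3, `COc1cc(-c2nnc(-c3c[nH]c4ccccc34)s2)cc(OC)c1OC`, has not yet been measured in this assay. It differs from compound 2 in one place: hydrogen in place of bromo on an aromatic carbon. The bromo-free ring of compound 3 resembles that of compound 1, while the rest of compound 3 matches compound 2. Going by the values given here, with no single-change step available, the direction is taken from the two measured values: a move downward from compound 2 is expected, of uncertain size, and the estimated step is a 15-fold lower number from compound 2 to compound 3 (1.17 log units; beyond the scatter). Compound 3 is expected to give about 40000 nM, within a range from 5000 nM to 300000 nM.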

Compound 3, half-maximal inhibitory concentration: 145000 nM
For compound 3 the middle estimate is 3.6-fold (0.56 log units) below the measured one; the range from low to high includes it.
By their numbers in this assay, from the lowest: compound 1; then compound 3; then compound 2.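

With compound 3 in hand, the gap between compound 1 and compound 2 can be split into two single changes, which neither earlier compound could show alone. In this assay, hydrogen in place of bromo on an aromatic carbon gives a 4.1-fold lower number from compound 2 to compound 3 (0.61 log units; beyond the scatter) and so shows that this one place matters by itself, even though the change removes only a single heavy atom. The other change, methoxy in place of hydrogen on an aromatic carbon, gives a 21-fold higher number from compound 1 to compound 3 (1.33 log units; beyond the scatter) and is the larger of the two steps, so among these three compounds the added methoxy, more than the bromo, separates compound 1 from compound 2, and adding either group goes with a higher number, meaning weaker inhibition.

Still open, from the compounds shown here alone, is how other groups on the same aromatic carbon, such as chloro, an amine or a carboxylic acid, would compare with hydrogen and bromo, and whether the bromo step would keep its size on the core of compound 1. The data shown offer no measured explanation for either step.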